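Removing the methyl from compound 3

The source may report more compounds than this note shows. Statements on the series, on what has been measured and on what is new or still open speak of the compounds shown alone.

In a functional assay on SK-MEL-5 cells (Homo sapiens) (a higher number here means a weaker inhibitor of growth, a lower number a stronger inhibitor of growth), compound 1 (`Cc1cc(C)c2c(O)cc(-c3ccc(Cl)cc3)nc2n1`) gives 14100 nM and compound 2 (`COc1ccc(-c2cc(O)c3cccnc3n2)cc1`) gives 34700 nM while compound 3 (`COc1ccccc1-c1cc(O)c2ccc(C)nc2n1`) gives 51300 nM as the third number. Compound 3 lies within the scatter of compound 2 and beyond the scatter of compound 1, whose number is lower. Compound 4 (`COc1ccccc1-c1cc(O)c2cccnc2n1`) has hydrogen in place of methyl on an aromatic carbon. For the measured compounds named here, no measured pair isolates this change. Compound 2 also lacks that methyl and gives 34700 nM within the scatter of compound 3, so no step beyond the scatter is expected in this assay for this change. The expected size is a 1.3-fold lower number from compound 3 to compound 4 (0.11 log units; within the scatter) and lies within the scatter. For compound 4 the estimated value is 40000 nM with an expected range from 20000 nM to 80000 nM in this series.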

Compound 4, concentration for 50% growth inhibition: 31600 nM
Compound 4: middle estimate off by 1.3-fold (0.10 log units), on the high side; the measured number falls inside the stated range.
By their numbers in this assay, from the lowest: compound 1; then compounds 4, 2 and 3 (each within the scatter of the next).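

In this assay, for the compounds shown here, the pair gives the first direct reading of this change: a 1.6-fold lower number from compound 3 to compound 4 (0.21 log units; within the scatter) stays within the scatter when hydrogen replaces the methyl next to the ring nitrogen. In this pair, the methyl at this place is not required to keep the growth inhibition seen for compound 3. No measurement available bears on the reason for this result.

On these data alone, whether an ethyl, an amine or a carboxylic acid at this carbon would shift the number beyond the scatter remains open. Also open, as far as these compounds go, is whether the same replacement would read alike in compound 1, which carries a methyl at this place too.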